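Swapping benzyloxy for dichlorophenyl on a cytotoxicity-silent scaffold

This account rests on a few compounds, and the source may have more. Where it says the series, first, only, none or still open, it means among the compounds named here.

Within the data shown here, the series rests on a shared core carrying a para-substituted phenyl arm, and the three compounds measured so far all sit at the same ceiling. Compound 1 `C=C[C@@](C)(/C=C/c1ccc(OCc2ccccc2)cc1)CCC=C(C)C` in a functional assay on HepG2 cells (Homo sapiens) for cytotoxicity, with a stated time of 72 h (on this read-out higher numbers stand for an effect only at larger amounts of compound and lower numbers for an effect already at smaller amounts), gives > 52000 nM, which is a limit of the assay rather than a number. Compound 2 `C=C[C@@](C)(/C=C/c1ccc(O)cc1)CC/C=C/C(=O)OCC` in this assay also returns a limit, > 52000 nM. Compound 3 `C=C[C@@](C)(/C=C/c1ccc(O)cc1)CC/C=C(C)/C=C/C(=O)OCC` in this assay likewise stops at a limit, > 52000 nM. So compound 1 stands nowhere distinct among the values shown: every one of them is the same limit, as the evidence summarises, (the limit of > 52000 nM in this assay, at which 3 of the 3 values shown sit).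

Compound 4 `C=C[C@@](C)(/C=C/c1ccc(-c2ccc(Cl)c(Cl)c2)cc1)CCC=C(C)C` is not yet measured. It differs from compound 1 in one place: 3,4-dichlorophenyl in place of benzyloxy on an aromatic carbon. Among the measured compounds shown here, no measured pair in the set bridges a change of this kind, so there is no step to lean on, and all three measured compounds carry only a limit.

The expectation for the step from compound 1 to compound 4 is at most a modest move toward lower numbers, an at least 1.3-fold lower number from compound 1 to compound 4 (0.11 log units; that floor lies within the scatter), with a real chance of no change beyond the scatter. Compound 4 is therefore estimated at 40000 nM, within a range from 12000 nM to 52000 nM, and it may well again report only a limit.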

Compound 4, half-maximal effective concentration: > 52000 nM
Compound 4 gave a limit, no number; the forecaster's own chance of this, stated with the estimate: 60%; at least 1.3-fold (0.11 log units) between middle value and limit.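

In this assay compound 4 gives > 52000 nM, a limit and not a number. Among these compounds, compound 1 also rests at a limit, so no step from one to the other of these two compounds can be read: the limit of > 52000 nM in this assay, at which 4 of the 4 values shown sit. The compounds shown leave open whether 3,4-dichlorophenyl and benzyloxy differ at all in this assay, since none of them gives a number.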